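The source may hold more compounds than are shown below. What is called first, only, known or untested is meant among the compounds shown, and "the series" means these compounds.

Measured so far:
compound 1, `CC(C)C(=O)OCOC(=O)C1=C(S[C@@H]2CN[C@H](C(=O)Nc3cccc(C(=O)O)c3)C2)[C@H](C)[C@@H]2[C@@H]([C@@H](C)O)C(=O)N12` — 15%
compound 2, `C[C@@H](O)[C@H]1C(=O)N2C(C(=O)OCOC(=O)OC(C)(C)C)=C(S[C@@H]3CN[C@H](C(=O)Nc4cccc(C(=O)O)c4)C3)[C@H](C)[C@H]12` — 40%
compound 3, `CCOC(=O)OCOC(=O)C1=C(S[C@@H]2CN[C@H](C(=O)Nc3cccc(C(=O)O)c3)C2)[C@H](C)[C@@H]2[C@@H]([C@@H](C)O)C(=O)N12` — 10%

In an ADME assay on a cell-free system (plasma, Homo sapiens) for metabolic stability, read by LC-MS, with a stated time of 60 min, at 37 degrees C, tested at 50 uM (a lower number here means that less of the compound is left, a higher number that more of the compound is left), compound 3 stands lowest of the three numbers, though its gap to compound 1 is within the scatter; only compound 2 lies clearly apart, as a number 30 percentage points lower from compound 2 to compound 3 (beyond the scatter) shows. Compound 4, `C[C@@H](O)[C@H]1C(=O)N2C(C(=O)OCC(F)(F)F)=C(S[C@@H]3CN[C@H](C(=O)Nc4cccc(C(=O)O)c4)C3)[C@H](C)[C@H]12`, differs from compound 3 in one place: trifluoromethyl in place of (ethoxycarbonyl)oxy on a saturated chain carbon bound to an oxygen next to a carbonyl group. Among the measured compounds shown here, two measured steps concern the same position. a number 5 percentage points lower from compound 1 to compound 3 (within the scatter) stayed within the scatter, while a number 30 percentage points lower from compound 2 to compound 3 (beyond the scatter) and a number 25 percentage points higher from compound 1 to compound 2 (beyond the scatter) were modest and beyond it, so changes at this position have moved the number only modestly so far. For the measured compounds named here, the change to compound 4 is larger than any of these, since the whole (ethoxycarbonyl)oxy group leaves and trifluoromethyl enters, and no measured pair shows this kind of exchange. The expectation for compound 4 is therefore uncertain and wide, with a step expected of about a number 40 percentage points higher from compound 3 to compound 4 (beyond the scatter) upward. Compound 4 is estimated at 50%, in a range from 20% to 85%.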

Compound 4, percent of the compound remaining: 80%
Estimate against measurement, compound 4: 30 percentage points below, and the stated range covers the measured number.
By their numbers in this assay, from the lowest: compounds 3 and 1 (each within the scatter of the next); then compound 2; then compound 4.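

In this assay, exchanging the whole (ethoxycarbonyl)oxy group for trifluoromethyl gives a number 70 percentage points higher from compound 3 to compound 4 (beyond the scatter) and the same exchange from the other two compounds gives a number 65 percentage points higher from compound 1 to compound 4 (beyond the scatter) and a number 40 percentage points higher from compound 2 to compound 4 (beyond the scatter), so all three steps into compound 4 are large. Among the compounds shown here, the earlier exchanges at this place, all among groups that keep a carbonyl in the side chain, moved the number only modestly or within the scatter, so this is the first sign that the place can carry a far larger change. Nothing available explains why the number moves so far.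

The compounds shown leave open whether trifluoromethyl itself is needed or whether a plain methyl, a fluoromethyl or a methoxy group on that saturated chain carbon would read the same. They also leave open how an amine or a longer chain there would stand in this assay, with the rest of the core unchanged.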